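A few compounds are considered here, and "the series" means these few. Any claim that something is new, unique, unknown or untested is made for them only; others in the source may bear on it.

Compound 1 `CCC(=O)N(C)c1ccc2[nH]c(-c3n[nH]c4ccccc34)cc2n1` gives 33500 nM in a functional assay on SMMC-7721 cells (Homo sapiens) for antiproliferative activity, read by MTT assay, with a stated time of 72 h; on this read-out higher numbers stand for weaker inhibition and lower numbers for stronger inhibition. Compound 2 `CN(C(=O)c1ccccc1)c1ccc2[nH]c(-c3n[nH]c4ccccc34)cc2n1`, with phenyl in place of ethyl on a carbonyl carbon, gives 12500 nM, and the step of a 2.7-fold lower number from compound 1 to compound 2 (0.43 log units; beyond the scatter). Compound 3 `CN(C(=O)c1ccccc1)c1ccc2[nH]c(-c3n[nH]c4cc(Cl)ccc34)cc2n1` gives 11300 nM, the lowest of the three numbers, although the step of a 1.1-fold lower number from compound 2 to compound 3 (0.04 log units; within the scatter), so compound 3 and compound 2 cannot be ranked against each other. Compound 4 `CN(C(=O)c1ccccc1)c1ccc2[nH]c(-c3n[nH]c4cc(C#N)ccc34)cc2n1` differs from compound 3 by cyano in place of chloro on an aromatic carbon. Among the compounds with values here, no measured step exchanges one substituent for another on that aromatic carbon; the only related step is a 1.1-fold lower number from compound 2 to compound 3 (0.04 log units; within the scatter), which lies within the scatter, so no step beyond the scatter is expected in this assay in either direction. Compound 4 is therefore estimated at 11000 nM, between 5500 nM and 22000 nM, an expected 1.0-fold lower number from compound 3 to compound 4 (0.01 log units; within the scatter).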

Compound 4, half-maximal inhibitory concentration: > 50000 nM
Compound 4: a limit, no number; the forecaster's own chance of this, stated with the estimate: 5%; middle value at least 4.5-fold (0.65 log units) away from the limit.
By their numbers in this assay, from the lowest: compounds 3 and 2 (each within the scatter of the next); then compound 1. At a limit, above all of these: compound 4.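

Chloro on this aromatic carbon stayed within the scatter of hydrogen, so the earlier compounds showed no sensitivity at this position. Cyano moves the number beyond the scatter, against both chloro (an at least 4.4-fold higher number from compound 3 to compound 4 (0.64 log units; beyond the scatter)) and hydrogen (an at least 4.0-fold higher number from compound 2 to compound 4 (0.60 log units; beyond the scatter)). As far as these compounds go, compound 4 carries a limit of the assay and not a number, so the full size of both steps stays unknown: (the limit of > 50000 nM in this assay, at which 1 of the 4 values shown sits).

From the compounds shown here alone, whether an amine, a methoxy group or a carboxylic acid on this carbon would follow chloro or cyano remains open. So does whether cyano would give the same step with the ethyl carbonyl of compound 1.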